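The source may report more compounds than this note shows. Statements on the series, on what has been measured and on what is new or still open speak of the compounds shown alone.

Compound 2 `Cc1ccc(C)c(-n2nncc2CN2C(=O)C3(C(C#N)=C(N)Oc4c(N)cc5nc6ccccc6nc5c43)c3ccccc32)c1` is the reference point for this step. In an ADME assay on L02 cells (Homo sapiens) for antiproliferative activity, read by MTT assay, with a stated time of 48 h (a lower number here means a stronger inhibitor, a higher number a weaker inhibitor), compound 2 gives > 50000 nM, which is a limit of the assay rather than a number. Among the compounds with values here, its only measured neighbour is compound 1 `N#CC1=C(N)Oc2c(N)cc3nc4ccccc4nc3c2C12C(=O)N(Cc1cnnn1-c1ccccc1Cl)c1ccccc12`, which carries 2-chlorophenyl on the aromatic nitrogen where compound 2 carries 2,5-dimethylphenyl. In this assay compound 1 gives > 50000 nM, again a limit. The step that the two limits leave unreadable from compound 1 to compound 2 therefore cannot be read, since (the limit of > 50000 nM in this assay, at which 2 of the 2 values shown sit).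

Compound 3 `COc1ccc(OC)c(-n2nncc2CN2C(=O)C3(C(C#N)=C(N)Oc4c(N)cc5nc6ccccc6nc5c43)c3ccccc32)c1` is the next member awaiting measurement. The change is 2,5-dimethoxyphenyl in place of 2,5-dimethylphenyl on an aromatic nitrogen. Within the data shown here, the one measured step that bears on a swap of the aryl group on this aromatic nitrogen is unreadable in size, and the two values shown agree only in sitting at the limit, because of the limit of > 50000 nM in this assay, at which 2 of the 2 values shown sit. No step beyond the usual scatter is expected from this exchange. The expected step is a step that the limit leaves unreadable from compound 2 to compound 3, that is, none beyond the scatter. Compound 3 is estimated at 60000 nM, within 30000 nM to 150000 nM, and is most likely reported again only as a limit.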

Compound 3, half-maximal inhibitory concentration: > 50000 nM
Compound 3 was reported as a limit; the forecaster's own chance of this, stated with the estimate: 80%; the middle value lies beyond the limit too.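

Neither the step from compound 2 to compound 3 nor the step from compound 1 to compound 3 can be read, since all three values are limits and not numbers: the limit of > 50000 nM in this assay, at which 3 of the 3 values shown sit.

The compounds shown leave open whether, in this assay, exchanging the aryl group on the aromatic nitrogen changes the value at all.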